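Moving a Methyl Group on the Urea Aryl Ring

A few compounds are considered here, and "the series" means these few. Any claim that something is new, unique, unknown or untested is made for them only; others in the source may bear on it.

Measured compounds:
compound 1, `Cc1ccc(NC(=O)Nc2cccc(CNc3nccnc3Cl)c2)cc1`, 11500 nM
compound 2, `CCOc1ccc(NC(=O)Nc2cccc(CNc3nccnc3Cl)c2)cc1`, 7050 nM
compound 3, `O=C(Nc1ccc(Cl)cc1)Nc1cccc(CNc2nccnc2Cl)c1`, 8350 nM

In a functional assay on HepG2 cells (Homo sapiens) for antiproliferative activity, read by MTT assay, with a stated time of 48 h (on this read-out lower numbers stand for stronger inhibition and higher numbers for weaker inhibition), compound 1 gives 11500 nM, the highest number of the three, though its gaps to compound 2 and compound 3 both lie within the scatter. Compound 4, `Cc1ccccc1NC(=O)Nc1cccc(CNc2nccnc2Cl)c1`, differs from compound 1 by 2-methylphenyl in place of 4-methylphenyl on an amide-type nitrogen. Among the measured compounds shown here, none of the measured steps moves a group to another place on its ring; each swaps one group for another at the same place: a 1.6-fold lower number from compound 1 to compound 2 (0.21 log units; within the scatter), a 1.4-fold lower number from compound 1 to compound 3 (0.14 log units; within the scatter) and a 1.2-fold higher number from compound 2 to compound 3 (0.07 log units; within the scatter), all within the scatter. On this evidence no step beyond the scatter is expected in this assay for compound 4. Compound 4 is therefore estimated at 11000 nM, with a range from 4000 nM to 30000 nM, meaning an expected 1.0-fold lower number from compound 1 to compound 4 (0.02 log units; within the scatter).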

Compound 4, half-maximal inhibitory concentration: 15300 nM
Compound 4: the middle estimate sits 1.4-fold (0.14 log units) below what was measured; measured number inside the range.
By their numbers in this assay, from the lowest: compounds 2, 3, 1 and 4 (each within the scatter of the next, the first and the last beyond it).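

In this assay, among the compounds shown here, the swap of 4-methylphenyl for 2-methylphenyl on the amide-type nitrogen, the first change of place on this ring, gives a 1.3-fold higher number from compound 1 to compound 4 (0.12 log units; within the scatter) and so leaves the number within the scatter, as does the swap with a 1.8-fold higher number from compound 3 to compound 4 (0.26 log units; within the scatter) alongside it. For the compounds shown here, only the swap with a 2.2-fold higher number from compound 2 to compound 4 (0.34 log units; beyond the scatter) passes the scatter, and only modestly, so compound 2 and compound 4 are the one pair here that separates. Nothing available explains that gap. The compounds shown leave open whether a carboxylic acid or an amine on this ring would move the number further than these groups do.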